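Butyl in place of methyl on the core of compound 2

The compounds below may be only part of what the source reports. "The series", "measured", "known", "first", "only" and "open" are said of these compounds alone.

Compound 1, `CCCCN(CC)c1nc(C)nc2c1ncn2-c1c(Cl)cc(OC)cc1OC`, and compound 2, `CCCCN(CC)c1nc(C)nc2c1nc(C)n2-c1c(Cl)cc(OC)cc1OC`, share one core and differ at a single aromatic carbon. In an in vitro assay on 293-EBNA cells for binding affinity to corticotropin-releasing factor receptor 1 (Homo sapiens) (a lower number here means a stronger inhibitor, a higher number a weaker inhibitor), compound 1 gives 5.2 nM, and compound 2 gives 3.5 nM. Among the compounds with values here, the step between them, a 1.5-fold lower number from compound 1 to compound 2 (0.17 log units; within the scatter), is the only step known, so compound 2 stands on a pair of numbers that cannot be told apart.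

Compound 3, `CCCCc1nc2c(N(CC)CCCC)nc(C)nc2n1-c1c(Cl)cc(OC)cc1OC`, carries the change (propyl in place of hydrogen on a saturated chain carbon bound to an aromatic carbon); cut one bond further out, the same difference reads methyl to butyl. Within the data shown here, no measured step touches this saturated chain carbon. Among the measured compounds shown here, the only step known, from compound 1 to compound 2, lies within the scatter and concerns a different place on the core, so it gives no direction for the present change. On that basis no step beyond the scatter is expected in this assay for compound 3, though the step is a guess.

Compound 3 is therefore expected to give 4 nM, between 1.3 nM and 12 nM, which means an estimated step of a 1.1-fold higher number from compound 2 to compound 3 (0.06 log units; within the scatter).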

Compound 3, inhibition constant: 22 nM
Compound 3: middle estimate off by 5.5-fold (0.74 log units), on the low side, outside the stated range (above it).
By their numbers in this assay, from the lowest: compounds 2 and 1 (each within the scatter of the next); then compound 3.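

At this carbon of the shared core, the earlier methyl in place of hydrogen gave no readable change in this assay (a 1.5-fold lower number from compound 1 to compound 2 (0.17 log units; within the scatter)), so the position had looked indifferent to substitution. The butyl group shows that it is not: extending the chain by propyl on the saturated chain carbon bound to the aromatic carbon gives a weaker inhibitor (a 6.3-fold higher number from compound 2 to compound 3 (0.80 log units; beyond the scatter)), and the comparison with hydrogen on the aromatic carbon runs the same way (a 4.2-fold higher number from compound 1 to compound 3 (0.63 log units; beyond the scatter)). No accompanying measurement bears on why the number rises with this change.

The compounds shown leave open how the number changes along the series from methyl to butyl, since ethyl and propyl on this aromatic carbon would be needed to tell a gradual rise from a sudden one above a certain chain length. They also leave open whether the loss belongs to the straight butyl chain itself or would persist with a branched isobutyl group, a cyclopropyl ring, or a chain ending in a hydroxyl group or an amine.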